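Triazole series on prostate cancer cells: benzyl for ethyl sulfide

The source may hold more compounds than are shown below. What is called first, only, known or untested is meant among the compounds shown, and "the series" means these compounds.

Compound 1 `CCSc1nnc(-c2cc(OC)c(OC)c(OC)c2)n1-c1ccc(OC)cc1` is the reference point; in a functional assay on PC-3 cells (Homo sapiens) for inhibition, read by MTT assay, with a stated time of 48 h (on this read-out higher numbers stand for weaker inhibition and lower numbers for stronger inhibition), compound 1 gives 57700 nM. Compound 2 `COc1ccc(-n2c(SCc3ccccc3)nnc2-c2cc(OC)c(OC)c(OC)c2)cc1` carries the change phenyl in place of methyl on a saturated chain carbon bound to a sulfur and in this assay compound 2 gives 34100 nM; the step is a 1.7-fold lower number from compound 1 to compound 2 (0.23 log units; within the scatter). Compound 3 `CCSc1nnc(-c2cc(OC)c(OC)c(OC)c2)n1-c1ccc(N(C)C)cc1` carries the other change, (dimethylamino in place of methoxy on an aromatic carbon), and in this assay compound 3 gives 46200 nM; the step is a 1.2-fold lower number from compound 1 to compound 3 (0.10 log units; within the scatter). All three numbers sit within the scatter of one another, so no order among them can be read.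

Compound 4 `COc1cc(-c2nnc(SCc3ccccc3)n2-c2ccc(N(C)C)cc2)cc(OC)c1OC` is not yet measured. It differs from compound 3 by phenyl in place of methyl on a saturated chain carbon bound to a sulfur, the same change as that from compound 1 to compound 2, at the same place, word for word. The two cores differ by dimethylamino in place of methoxy on an aromatic carbon, a change that itself made only a small step.

The step in this assay from compound 3 to compound 4 is expected to be a 1.7-fold lower number from compound 3 to compound 4 (0.23 log units; within the scatter), resting on the earlier step of a 1.7-fold lower number from compound 1 to compound 2 (0.23 log units; within the scatter) and on the near-identical numbers of compound 1 and compound 3. Compound 4 is therefore estimated at 27000 nM, with a range from 12000 nM to 60000 nM.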

Compound 4, half-maximal inhibitory concentration: 55800 nM
Compound 4: middle estimate off by 2.1-fold (0.32 log units), on the low side; low and high end bracket the measured number.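

In this assay, ethylsulfanyl to benzylsulfanyl on the dimethylamino core gives a 1.2-fold higher number from compound 3 to compound 4 (0.08 log units; within the scatter), and dimethylamino in place of methoxy on the benzylsulfanyl core gives a 1.6-fold higher number from compound 2 to compound 4 (0.21 log units; within the scatter); both steps lie within the scatter. Carried from one core to the other, the benzyl change shows no difference that can be told from the scatter: the same change on two cores in this assay, a 1.7-fold lower number (0.23 log units; within the scatter) from compound 1 to compound 2 and a 1.2-fold higher number (0.08 log units; within the scatter) from compound 3 to compound 4, 2.0-fold (0.31 log units) apart, within the scatter of two such steps

The dimethylamino change reads the same way, and these pairs show neither that either change has a real effect on this read-out nor that a real effect carries over between cores, only that no difference can be resolved here: the same change on two cores in this assay, a 1.2-fold lower number (0.10 log units; within the scatter) from compound 1 to compound 3 and a 1.6-fold higher number (0.21 log units; within the scatter) from compound 2 to compound 4, 2.0-fold (0.31 log units) apart, within the scatter of two such steps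

Left open is whether any change at these two places can give a step beyond the scatter in this assay. A longer chain such as butyl on the sulfur, or a carboxylic acid or a primary amine in place of the methoxy or dimethylamino group, would fall outside the compounds shown.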